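One Ring Atom Changed: From Compound 1 to Compound 4

This account rests on a few compounds, and the source may have more. Where it says the series, first, only, none or still open, it means among the compounds named here.

Measured so far in a functional assay on NCI-H460 cells (Homo sapiens) for antiproliferative activity, read by CCK-8 assay, with a stated time of 72 h, tested at 8 uM; on this read-out higher numbers stand for a stronger effect at the one concentration tested and lower numbers for a weaker effect:
- compound 1 `CN1CCN(c2nc(Cl)nc3c2ncn3Cc2ccc(C(=O)Nc3ccccc3N)cc2)CC1`: 55.1%
- compound 2 `CC(C)n1cnc2c(Nc3ccccc3)nc(NCOCc3ccc(C(=O)Nc4ccccc4N)cc3)nc21`: 34.3%
- compound 3 `Nc1ccccc1NC(=O)/C=C/c1ccc(COCNc2nc(Nc3cccc(Cl)c3)c3ncn(C4CCCC4)c3n2)cc1`: 46.1%

Among these three, compound 1 gives the largest number. Compound 3 comes closest to it, and the gap between the two lies within the usual scatter of this assay, so the two cannot be told apart. Compound 2 lies further off, and that gap is beyond the scatter, so compound 2 shows a genuinely weaker effect than compound 1.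

Compound 4 `CC1CCN(c2nc(Cl)nc3c2ncn3Cc2ccc(C(=O)Nc3ccccc3N)cc2)CC1` has not yet been tested. It is built from compound 1 by a single change: 4-methylpiperidin-1-yl in place of 4-methylpiperazin-1-yl on an aromatic carbon. Every other part of the molecule stays the same.

Within the data shown here, no pair of measured compounds differs in one place, so there is no directly comparable step to lean on. With the two groups alike in size and in ring shape, the change is expected to move the number little, if at all; the step of a number 5.1 percentage points lower from compound 1 to compound 4 (within the scatter) is estimated to stay within the scatter, with a slight lean toward a weaker effect rather than a stronger one.

For compound 4, the expected result in this assay is 50%, with a likely range from 30% to 68%.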

Compound 4, a percentage reported as inhibition, at one concentration (the size of the read-out at that concentration, not a potency): 40.9%
Beside the measured number, compound 4's estimate is 9.1 percentage points above it, within the range that was stated.
By their numbers in this assay, from the lowest: compounds 2, 4, 3 and 1 (each within the scatter of the next, the first and the last beyond it).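

In this assay, among these compounds, placing 4-methylpiperidin-1-yl instead of 4-methylpiperazin-1-yl on the aromatic carbon gives a number 14.2 percentage points lower from compound 1 to compound 4 (beyond the scatter), and this is the first comparison here in which only one part of the molecule differs. It shows that this position is sensitive to more than the size and shape of the group: both groups have the same number of heavy atoms and a six-membered non-aromatic ring, yet replacing the nitrogen that carries the methyl with a carbon is enough to weaken the effect at the one concentration tested. No measurement shown here explains the drop.

As far as these compounds go, this single step cannot separate the importance of that ring nitrogen from the way it is substituted, so it remains open whether morpholin-4-yl, with an oxygen at that ring place, or piperazin-1-yl, without the methyl, would read closer to compound 1 or to compound 4. From the compounds shown here alone, it is also open whether the same exchange would give a similar step if an amine stood in place of the chloro group on the shared core.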